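Open-chain and cyclic amides: allyl to phenyl on nitrogen

A few compounds are considered here, and "the series" means these few. Any claim that something is new, unique, unknown or untested is made for them only; others in the source may bear on it.

Measured so far:
- compound 1 `C=CCN/C(SC)=C(/C#N)C(=O)Nc1ccc(OCC)cc1`: 8850 nM
- compound 2 `CCOc1ccc(NC(=O)c2c(N)n[nH]c2Nc2ccccc2)cc1`: 4320 nM
- compound 3 `C=CCNc1[nH]nc(N)c1C(=O)Nc1ccc(OCC)cc1`: 22000 nM

All numbers come from a functional assay on Huh-7 cells (Homo sapiens) for cytotoxicity, read by resazurin assay, with a stated time of 48 h; on this read-out higher numbers stand for weaker inhibition and lower numbers for stronger inhibition. The change from compound 3 to compound 2, (phenyl in place of allyl on a nitrogen on an aromatic ring), gave a 5.1-fold lower number from compound 3 to compound 2 (0.71 log units; beyond the scatter). The same change is now made on compound 1, giving compound 4 `CCOc1ccc(NC(=O)/C(C#N)=C(\Nc2ccccc2)SC)cc1`, as phenyl in place of allyl on an amine nitrogen. The difference between the two cores is not broken down here. The place is not identical: in the measured pair the nitrogen sits on an aromatic ring with an aromatic carbon as its other neighbour, whereas in compound 1 it is an amine nitrogen whose other neighbour is a double-bonded chain carbon, so this is the same kind of change rather than the same one. Compound 1 itself stands second highest of the three values, its nearest neighbour being compound 2. A step of similar direction but uncertain size is expected, a 3.5-fold lower number from compound 1 to compound 4 (0.55 log units; beyond the scatter), because the measured pair shows a 5.1-fold lower number from compound 3 to compound 2 (0.71 log units; beyond the scatter) on a different core. Compound 4 is therefore estimated at 2500 nM, within 900 nM to 7000 nM.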

Compound 4, half-maximal inhibitory concentration: 25300 nM
Compound 4: middle estimate off by 10-fold (1.01 log units), on the low side; measured number outside the range, above it.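

In this assay, phenyl in place of allyl on an amine nitrogen gave a 2.9-fold higher number from compound 1 to compound 4 (0.46 log units; beyond the scatter), so the earlier step on the other core does not predict this one. The change does not carry from one core to the other in this series, in direction or in size: the same change on two cores in this assay, a 5.1-fold lower number (0.71 log units; beyond the scatter) from compound 3 to compound 2 and a 2.9-fold higher number (0.46 log units; beyond the scatter) from compound 1 to compound 4, 15-fold (1.16 log units) apart, beyond the scatter of two such steps

These two pairs show only that the outcome of this change differs between these two cores; they do not show which feature of the cores accounts for it, or how the change would behave on a third core.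

Going by these compounds, it remains open how a benzyl or cyclopropyl group on this nitrogen would compare with allyl and phenyl on each core. A longer chain in place of the methylthio group of compound 4 is also an open question.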